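Chloro for Fluoro on the Urea Aryl Ring

A few compounds are considered here, and "the series" means these few. Any claim that something is new, unique, unknown or untested is made for them only; others in the source may bear on it.

Two compounds share a core and differ only in the aryl group at the far end of a urea. Compound 1 `COc1ccc(NC(=O)Nc2cccc(CNc3ncnc4cc(OC)c(OC)cc34)c2)cc1` gives 24500 nM in a functional assay on A549 cells (Homo sapiens) for antiproliferative activity, read by MTT assay; a higher number here means a weaker inhibitor, a lower number a stronger inhibitor. Compound 2 `COc1cc2ncnc(NCc3cccc(NC(=O)Nc4ccccc4F)c3)c2cc1OC` gives 23800 nM in this assay. The step of a 1.0-fold lower number from compound 1 to compound 2 (0.01 log units; within the scatter) is within the scatter, so the two numbers cannot be told apart, and compound 2 stands alongside compound 1 rather than apart from it.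

Compound 3 `COc1cc2ncnc(NCc3cccc(NC(=O)Nc4ccccc4Cl)c3)c2cc1OC` is not yet measured. It differs from compound 2 by chloro in place of fluoro on an aromatic carbon. Among the measured compounds shown here, the only measured step touching this aryl ring, a 1.0-fold lower number from compound 1 to compound 2 (0.01 log units; within the scatter), shows that even a larger change there left the number unmoved. A single halogen swap is therefore expected to give no step beyond the scatter, a 1.1-fold lower number from compound 2 to compound 3 (0.03 log units; within the scatter). Compound 3 is estimated at 22000 nM in this assay, with a range from 9000 nM to 55000 nM.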

Compound 3, half-maximal inhibitory concentration: 15200 nM
Compound 3: the middle estimate sits 1.4-fold (0.16 log units) above what was measured, within the range that was stated.
By their numbers in this assay, from the lowest: compounds 3, 2 and 1 (each within the scatter of the next).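

In this assay, chloro in place of fluoro on this aromatic carbon, ortho to a large group, gives a 1.6-fold lower number from compound 2 to compound 3 (0.19 log units; within the scatter) and so joins the earlier aryl change as a step that cannot be told apart from repeat-measurement noise. Swapping the whole end group, 2-chlorophenyl in place of 4-methoxyphenyl, gives a 1.6-fold lower number from compound 1 to compound 3 (0.21 log units; within the scatter) as well, which places all three aryl groups shown within the scatter of one another. No measurement available here explains this flat reading.

Still open, on these data alone, is whether any group on this ring can move the number beyond the scatter, such as a trifluoromethyl, an amine or a carboxylic acid. The compounds shown also leave open whether a change in the shared core would do so.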